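Bromo for hydroxymethyl on the thiophene-bearing core

The source may report more compounds than this note shows. Statements on the series, on what has been measured and on what is new or still open speak of the compounds shown alone.

Compound 1 `CN(CCCCc1ccccc1)C1CCc2ccsc2CC1` gives 17 nM in an assay on membranes from brain for displacement of a labelled ligand from Sigma non-opioid intracellular receptor 1 (Cavia porcellus), read by scintillation counting, with a stated time of 120 min; a lower number here means a stronger inhibitor, a higher number a weaker inhibitor. Compound 2 `OCc1cc2c(s1)CCC(NCCCc1ccccc1)CC2` gives 61 nM in this assay, and compound 3 `OCc1cc2c(s1)CCC(NCCCCc1ccccc1)CC2` gives 84 nM. Among the compounds with values here, the one step between measured compounds that differ in a single place, a 1.4-fold higher number from compound 2 to compound 3 (0.14 log units; within the scatter), involves the chain length and not the substituent on the aromatic ring. Compound 3 has the highest number of the three; its nearest neighbour is compound 2, within the scatter, and compound 1 lies furthest away, beyond the scatter.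

Compound 4 `Brc1cc2c(s1)CCC(NCCCCc1ccccc1)CC2` differs from compound 3 by bromo in place of hydroxymethyl on an aromatic carbon. Within the data shown here, no measured step changes this position, so nothing among the three measured compounds bears directly on the exchange; compound 1, which has no substituent on that ring and a different amine, only shows that the shared core without the hydroxymethyl group can give a lower number. The expected step of a 1.7-fold lower number from compound 3 to compound 4 (0.23 log units; within the scatter) is therefore small and uncertain, leaning toward a lower number but within the scatter. Compound 4 is estimated at 50 nM, in the range 12 nM to 200 nM.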

Compound 4, inhibition constant: 14 nM
The estimate for compound 4 lay 3.6-fold (0.55 log units) above the measured number; measured number inside the range.
By their numbers in this assay, from the lowest: compounds 4 and 1 (each within the scatter of the next); then compounds 2 and 3 (each within the scatter of the next).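

Bromo in place of hydroxymethyl gives the first measured step at this position, next to the ring sulfur: a 6.0-fold lower number from compound 3 to compound 4 (0.78 log units; beyond the scatter). The substituent here therefore matters in this assay, and the hydroxymethyl group, with its hydrogen-bond donor and acceptor, is not required for compound 4 to reach 14 nM. Nothing shown accounts for the size of this step.

From the compounds shown here alone, it remains open how chloro, methyl or a carboxylic acid on this aromatic carbon would compare with bromo, and whether a bare ring carbon there would match bromo with the chain of compound 4. Also open, going by these compounds, is whether the same exchange would give a step of similar size with the shorter chain of compound 2.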